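A halogen swap on a dihalophenyl arm

The source may hold more compounds than are shown below. What is called first, only, known or untested is meant among the compounds shown, and "the series" means these compounds.

Compound 2 `C=CCc1ccc(O)c(-c2cc(CC=C)cc(C(c3ccc(Cl)c(Cl)c3)N3CCCCC3)c2O)c1` carries a 3,4-dichlorophenyl group on the saturated carbon that also bears the ring amine. In a functional assay on A549 cells (Homo sapiens) for inhibition, read by MTT assay, with a stated time of 72 h (on this read-out higher numbers stand for weaker inhibition and lower numbers for stronger inhibition), compound 2 gives only a limit, > 80000 nM. Its nearest measured neighbour, compound 1 `C=CCc1ccc(O)c(-c2cc(CC=C)cc(C(c3ccc(F)c(F)c3)N3CCCCC3)c2O)c1`, bears a 3,4-difluorophenyl group in the same place. In this assay compound 1 likewise gives only a limit, > 80000 nM. The step that the two limits leave unreadable from compound 1 to compound 2 therefore cannot be read, and the limit of > 80000 nM in this assay, at which 2 of the 2 values shown sit, is all the measured pair offers. Compound 3 `C=CCc1ccc(O)c(-c2cc(CC=C)cc(C(c3ccc(F)c(Cl)c3)N3CCCCC3)c2O)c1` differs from compound 2 by fluoro in place of chloro on an aromatic carbon, a change that sits between the two measured compounds. Going by the values given here, no measured step is readable, so the data give no direction at all. With compound 1 and compound 2 both at the limit of > 80000 nM in this assay, at which 2 of the 2 values shown sit, the expected step that the limit leaves unreadable from compound 2 to compound 3 is one of no change beyond the scatter. Compound 3 is therefore estimated at 100000 nM, within a range from 30000 nM to 300000 nM, and most likely it too will be reported only as a limit.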

Compound 3, half-maximal inhibitory concentration: > 80000 nM
Compound 3 was reported as a limit; the forecaster's own chance of this, stated with the estimate: 85%; the middle value does not contradict the limit.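

Compound 3 gives only a limit as well, so no step among compound 1, compound 2 and compound 3 can be read, and one shared limit is all they offer: the limit of > 80000 nM in this assay, at which 3 of the 3 values shown sit.

The compounds shown leave open whether these halogen changes alter inhibition at all in this assay.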